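The compounds below may be only part of what the source reports. "The series", "measured", "known", "first", "only" and "open" are said of these compounds alone.

In a physicochemical assay for solubility, read by HPLC, using the shake flask method, in phosphate buffer, with a stated time of 20 h, at pH 6.5 (a higher number here means a more soluble compound, a lower number a less soluble compound), compound 3 (`CN1CCN(C2CCN(c3nccc4[nH]c(-c5ccc(F)c(F)c5)nc34)CC2)CC1`) gives 130000 nM and so stands level with compound 1 (`CN1CCN(c2nccc3nc(-c4ccc(F)c(F)c4)[nH]c23)CC1`), which gives 130000 nM too. Compound 2 (`NC1CCN(c2nccc3[nH]c(-c4ccc(F)c(F)c4)nc23)CC1`) gives 200000 nM and lies within the usual scatter of both, so these numbers do not rank the three compounds.

Compound 4 (`CN1CCN(C(=O)C2CCN(c3nccc4[nH]c(-c5ccc(F)c(F)c5)nc34)CC2)CC1`) has not yet been measured. It differs from compound 3 by one swap on a saturated ring carbon, with (4-methylpiperazin-1-yl)carbonyl in place of 4-methylpiperazin-1-yl ((4-methylpiperazin-1-yl)carbonyl in place of 4-methylpiperazin-1-yl on a saturated ring carbon). The entering group keeps the six-membered ring and adds a carbonyl.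

Among the measured compounds shown here, only one measured step bears on this change. It is a 1.5-fold lower number from compound 2 to compound 3 (0.19 log units; within the scatter) and it is also a swap on a saturated ring carbon, one that stays within the scatter. For the measured compounds named here, no measured pair here shows what adding a carbonyl at this place does, so the evidence is thin and the range must stay wide. On that basis, the expected step is a 1.2-fold lower number from compound 3 to compound 4 (0.07 log units; within the scatter) and no change beyond the scatter is expected. Compound 4 is estimated at 110000 nM with an expected range from 45000 nM to 220000 nM on the same scale.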

Compound 4, solubility: 200000 nM
Estimate against measurement, compound 4: 1.8-fold (0.26 log units) below; measured number inside the range.
By their numbers in this assay, from the lowest: compounds 1, 3, 2 and 4 (each within the scatter of the next).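

In this assay, among the compounds shown here, replacing 4-methylpiperazin-1-yl with (4-methylpiperazin-1-yl)carbonyl on a saturated ring carbon gives a 1.5-fold higher number from compound 3 to compound 4 (0.19 log units; within the scatter) and provides the first measured reading of a carbonyl at this place. Replacing amino with the same (4-methylpiperazin-1-yl)carbonyl group gives no change at the digits printed from compound 2 to compound 4 (within the scatter) and adds a second reading, so compounds 2, 3 and 4 are not told apart by this measurement, even though the group at this place ranges from amino to one of 9 heavy atoms. Nothing measured here bears on the cause of this result.

As far as these compounds go, what a carboxylic acid or a longer alkyl chain would do on this saturated ring carbon remains open, as does what a carbonyl would do when joined to a group other than 4-methylpiperazin-1-yl. The compounds shown also leave open whether a carbonyl placed elsewhere on this six-membered ring would give a step beyond the usual scatter of repeated measurements.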